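The source may hold more compounds than are shown below. What is called first, only, known or untested is meant among the compounds shown, and "the series" means these compounds.

Measured compounds:
Compound 1, `Cc1ccccc1-n1nncc1CN1C(=O)C2(C(C#N)=C(N)Oc3c2c2nc4ccccc4nc2c2ccccc32)c2ccccc21`: in a functional assay on A549 cells (Homo sapiens) for antiproliferative activity, read by MTT assay, with a stated time of 48 h (on this read-out lower numbers stand for stronger inhibition and higher numbers for weaker inhibition), compound 1 reaches only the limit of the assay, > 50000 nM.
Compound 2, `N#CC1=C(N)Oc2c(c3nc4ccccc4nc3c3ccccc23)C12C(=O)N(Cc1cnnn1-c1ccc(Br)cc1)c1ccccc12`: in this assay compound 2 gives 44300 nM.
Compound 3, `N#CC1=C(N)Oc2c(c3nc4ccccc4nc3c3ccccc23)C12C(=O)N(Cc1cnnn1-c1ccccc1Br)c1ccccc12`: in this assay compound 3 again sits at the limit of the assay, > 50000 nM.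

Compound 3 thus stands at the top of what this assay can report, and it shares that position with compound 1, as the limit of > 50000 nM in this assay, at which 2 of the 3 values shown sit, shows. Compound 2 is the only one of the three with a number, and that number is close to the same ceiling. The steps between them are small or unreadable: an at least 1.1-fold lower number from compound 1 to compound 2 (0.05 log units; that floor lies within the scatter), an at least 1.1-fold higher number from compound 2 to compound 3 (0.05 log units; that floor lies within the scatter), and a step that the two limits leave unreadable from compound 1 to compound 3. Across these three compounds, exchanging the group on the aromatic nitrogen of the five-membered aromatic ring with 3 nitrogen has produced nothing that rises above the scatter.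

Compound 4, `CC(=O)Nc1ccc(-n2nncc2CN2C(=O)C3(C(C#N)=C(N)Oc4c3c3nc5ccccc5nc3c3ccccc43)c3ccccc32)cc1`, continues the same exchange: 4-acetamidophenyl in place of 2-bromophenyl on an aromatic nitrogen. For the measured compounds named here, none of the measured steps shows that this position moves the read-out, so the expectation for compound 4 is a step of about a number no higher from compound 3 to compound 4 (the limit leaves the size open), that is, no change beyond the scatter. Compound 4 is therefore estimated at 50000 nM, within 15000 nM to 150000 nM, with a fair chance that this assay again reports only its limit.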

Compound 4, half-maximal inhibitory concentration: > 50000 nM
Compound 4: only a limit was reported (the forecaster's own chance of this, stated with the estimate: 60%); the middle value sits exactly at the limit.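

The 4-acetamidophenyl group brings a hydrogen-bond donor and a hydrogen-bond acceptor to the aromatic nitrogen, which none of the earlier aryl groups has, yet in this assay compound 4 again gives only a limit, > 50000 nM. For the compounds shown here, the one step that can be read is an at least 1.1-fold higher number from compound 2 to compound 4 (0.05 log units; that floor lies within the scatter), while the other steps to compound 4 cannot be read, as both of their ends are limits. Acetamido in place of bromo on the aromatic carbon therefore gives no change beyond the scatter, and the wider and more varied set of aryl groups still leaves the series at the ceiling of the read-out: the limit of > 50000 nM in this assay, at which 3 of the 4 values shown sit.

From the compounds shown here alone, whether real differences lie hidden behind the limit among compound 1, compound 3 and compound 4 stays open, as the read-out gives no numbers for them to compare. Also open, going by these compounds, is whether a carboxylic acid, an amine or a longer chain in place of the aryl ring on this nitrogen, or a change in the shared core, would bring the values clearly below the limit.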